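Methoxycarbonyl to benzylcarbamoyl on the shared core

The source may hold more compounds than are shown below. What is called first, only, known or untested is meant among the compounds shown, and "the series" means these compounds.

Going by the values given here, compound 1 `COC(=O)c1cc(CCCOc2c(C)cc(-c3noc(C(F)(F)F)n3)cc2C)on1` is the only member of the set with a number in an ADME assay on HeLa cells (Homo sapiens) for cytotoxicity, read by crystal violet staining, with a stated time of 72 h (a higher number here means that more compound is tolerated, a lower number that less compound is tolerated), where compound 1 gives 35400 nM. Compound 2 `CCOC(=O)c1cc(CCCOc2ccc(-c3noc(C(F)(F)F)n3)cc2OC)on1` reaches only a limit in this assay, > 100000 nM. Compound 3 `CCOC(=O)c1cc(CCCOc2c(OC)cc(-c3noc(C(F)(F)F)n3)cc2[N+](=O)[O-])on1` likewise stops at a limit in this assay, > 100000 nM. Among the compounds with values here, the one step between measured compounds, a step that the two limits leave unreadable from compound 2 to compound 3, therefore cannot be read in size, and the limit of > 100000 nM in this assay, at which 2 of the 3 values shown sit, marks where two of the three values sit.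

Compound 4 `Cc1cc(-c2noc(C(F)(F)F)n2)cc(C)c1OCCCc1cc(C(=O)NCc2ccccc2)no1` differs from compound 1 in one place: benzylamino in place of methoxy on a carbonyl carbon. Within the data shown here, no measured step in the set touches the carbonyl carbon; the step from compound 2 to compound 3 concerns another part of the core and has no readable size. What enters is much larger than what leaves, yet nothing measured here speaks to the effect of such a change on tolerated concentration. In this assay no step beyond the scatter is expected, and the range is kept wide to allow either direction. The estimate means a step of a 1.2-fold lower number from compound 1 to compound 4 (0.07 log units; within the scatter). Compound 4 is expected at 30000 nM, within 8000 nM to 100000 nM, with a fair chance that only a limit is returned.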

Compound 4, half-maximal cytotoxic concentration: > 100000 nM
Compound 4: only a limit was reported; the forecaster's own chance of this, stated with the estimate: 25%; middle value at least 3.3-fold (0.52 log units) from the limit.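

In this assay, going by these compounds alone, the change from methoxycarbonyl to benzylcarbamoyl gives an at least 2.8-fold higher number from compound 1 to compound 4 (0.45 log units; beyond the scatter), the first step with a readable size and the first evidence on this carbonyl carbon. Going by these compounds, compound 4 gives > 100000 nM, which is a limit and not a number, so the step has a lower bound only and its true size stays unknown. Within the data shown here, the position therefore takes benzylamino, with its six-membered aromatic ring and the amide hydrogen, with no fall in the tolerated concentration, while compound 1 remains the only member of the series with a number: the limit of > 100000 nM in this assay, at which 3 of the 4 values shown sit.

On these data alone, it remains open whether the step belongs to the amide itself or to the benzyl group, a question that methylamino or a carboxylic acid on the same carbonyl carbon could separate. As far as these compounds go, it is also open whether a change at this carbon reads the same on the cores of compound 2 and compound 3, since a step from a limit has no readable size and any further compound reaching that limit would add little.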